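Replacing an Aminohexyl Tail with a Hydroxy-Ether Chain

This account rests on a few compounds, and the source may have more. Where it says the series, first, only, none or still open, it means among the compounds named here.

Measured so far:
Compound 1 `NCCCCCCOc1ccc2c(=O)c(-c3ccc(O)cc3)coc2c1` gives 100 nM.
Compound 2 `C=CCCCCOc1ccc2c(=O)c(-c3ccc(O)cc3)coc2c1` gives 150 nM.
Compound 3 `O=C(O)COc1ccc2c(=O)c(-c3ccc(O)cc3)coc2c1` gives 1200 nM.

All three share one core and differ only in the chain hung from the aromatic oxygen. In an assay (Cricetulus griseus) for inhibition of aldehyde dehydrogenase, mitochondrial (Homo sapiens) (a lower number here means a stronger inhibitor, a higher number a weaker inhibitor), compound 1 has the lowest number of the three; compound 2 sits nearest to it, with a 1.5-fold higher number from compound 1 to compound 2 (0.18 log units; within the scatter), while compound 3 lies furthest away, with a 12-fold higher number from compound 1 to compound 3 (1.08 log units; beyond the scatter). The new compound, compound 4 `O=c1c(-c2ccc(O)cc2)coc2cc(OCCOCCOCCO)ccc12`, keeps the core of compound 1 and changes its chain: 2-(2-hydroxyethoxy)ethoxy in place of 4-aminobutyl on a saturated chain carbon, two bonds along the chain from an oxygen on an aromatic ring.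

Two measured steps speak to this change. The step of a 1.5-fold higher number from compound 1 to compound 2 (0.18 log units; within the scatter) shows that swapping the terminal amine for a vinyl group leaves the number essentially where it was, so the amine itself does not seem to carry much of the potency. The steps of a 12-fold higher number from compound 1 to compound 3 (1.08 log units; beyond the scatter) and an 8.0-fold higher number from compound 2 to compound 3 (0.90 log units; beyond the scatter) show that a short carboxy-bearing chain costs clearly more. Compound 4 keeps a long, uncharged, flexible chain ending in a hydroxyl, which resembles compound 1 and compound 2 more than compound 3. Compound 4 is therefore expected to give a somewhat higher number than compound 1, by a step of about a 2.5-fold higher number from compound 1 to compound 4 (0.40 log units; beyond the scatter), possibly within the scatter. The estimate for compound 4 in this assay is 250 nM, with a range from 80 nM to 800 nM.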

Compound 4, half-maximal inhibitory concentration: 40 nM
The estimate for compound 4 lay 6.3-fold (0.80 log units) above the measured number; the whole stated range lies above it.
By their numbers in this assay, from the lowest: compound 4; then compounds 1 and 2 (each within the scatter of the next); then compound 3.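

In this assay, the swap of 4-aminobutyl for 2-(2-hydroxyethoxy)ethoxy gives a 2.5-fold lower number from compound 1 to compound 4 (0.40 log units; beyond the scatter), and the comparison with the alkene-ended chain gives a 3.8-fold lower number from compound 2 to compound 4 (0.57 log units; beyond the scatter); the chain at this position therefore matters among long chains too, which compounds 1 and 2, within the scatter of each other, had not shown. The distance from the short carboxy-bearing chain grows to a 30-fold lower number from compound 3 to compound 4 (1.48 log units; beyond the scatter), and with all three of its steps beyond the scatter, compound 4 stands as the strongest inhibitor of the four. Why the ether chain gives the lowest number cannot be said, as nothing at hand bears on the cause.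

The chain of compound 4 differs from that of compound 1 in both its ether oxygens and its terminal hydroxyl, so these compounds do not separate the two; a plain hexyl chain ending in a hydroxyl, or the same ether chain ending in an amine or a carboxylic acid, would bear on that question. From the compounds shown here alone, how a longer or a shorter ether chain would fare at this position also remains open.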